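Notes on the step from compound 1 to compound 4

The source may hold more compounds than are shown below. What is called first, only, known or untested is meant among the compounds shown, and "the series" means these compounds.

- compound 1 `Cn1cc(C(=O)N2CC3(C2)CN(c2cncc(N4C(=O)c5ccc(Cl)cc5C4(C)C)c2)C3)cn1`: 6.4 mL/min/kg
- compound 2 `CCC(=O)N[C@@H]1CCCc2c1cncc2N1CCc2cc(Cl)ccc2C1=O`: < 20.2 mL/min/kg (a limit)
- compound 3 `CS(=O)(=O)N[C@@H]1CCCc2c1cncc2N1CCc2cc(Cl)ccc2C1=O`: < 20.2 mL/min/kg (a limit)

Going by the values given here, in an ADME assay on microsomes from liver (Rattus norvegicus) for metabolic stability, read by LC-MS, using NADPH, with stated times of 10 min and 30 min (on this read-out higher numbers stand for fast clearance and lower numbers for slow clearance), compound 1 gives 6.4 mL/min/kg, the only actual number in this set. The other two results are limits and not numbers: the limit of < 20.2 mL/min/kg in this assay, at which 2 of the 3 values shown sit.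

Compound 4 `CCS(=O)(=O)N1CC2(CN(c3cncc(N4C(=O)c5ccc(Cl)cc5C4(C)C)c3)C2)C1` is still unmeasured and carries ethylsulfonyl in place of (1-methyl-1H-pyrazol-4-yl)carbonyl on an amine nitrogen in a ring. The nearest measured change is a step that the two limits leave unreadable from compound 2 to compound 3, with methylsulfonyl in place of propanoyl on an amine nitrogen. It offers neither size nor direction, so no shift beyond the scatter is expected in this assay. The expected change is a 1.3-fold higher number from compound 1 to compound 4 (0.10 log units; within the scatter). For compound 4 the estimate is 8 mL/min/kg, with an expected range from 4 mL/min/kg to 20 mL/min/kg.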

Compound 4, clearance: 0.87 mL/min/kg
For compound 4 the middle estimate is 9.2-fold (0.96 log units) above the measured one; measured number below the stated range.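

In this assay, ethylsulfonyl in place of (1-methyl-1H-pyrazol-4-yl)carbonyl on this amine nitrogen in a ring gives a 7.4-fold lower number from compound 1 to compound 4 (0.87 log units; beyond the scatter), so the read-out responds to the group at this position. Going by these compounds alone, this is the first readable step involving a sulfonyl group. The step from compound 2 to compound 3 cannot be read, because both results are limits and not numbers: the limit of < 20.2 mL/min/kg in this assay, at which 2 of the 4 values shown sit.

The compounds shown leave open whether the lower number goes with the sulfonyl group or with the loss of the five-membered aromatic ring. As far as these compounds go, how an acetyl group or a longer chain on the sulfonyl group would read at this nitrogen also stays open.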